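Isomeric boron-containing groups and antiproliferative potency

The source may hold more compounds than are shown below. What is called first, only, known or untested is meant among the compounds shown, and "the series" means these compounds.

Three compounds that differ only in how one boron-containing group is joined to a shared chain have been measured in a functional assay on HCT-116 cells (Homo sapiens) for antiproliferative activity, read by MTT assay, with a stated time of 72 h; a higher number here means a weaker inhibitor, a lower number a stronger inhibitor. Compound 1 `COc1cc(OC)cc(-c2cccc(NC(=O)CCc3cccc4c3B(O)OC4)c2)c1` gives 53 nM, compound 2 `COc1cc(OC)cc(-c2cccc(NC(=O)CCc3ccc4c(c3)B(O)OC4)c2)c1` gives 3700 nM, and compound 3 `COc1cc(OC)cc(-c2cccc(NC(=O)CCc3ccc4c(c3)COB4O)c2)c1` gives 56000 nM. Compound 3 therefore has the highest number and is the weakest of the three. Compound 4 `COc1cc(OC)cc(-c2cccc(NC(=O)CCc3cccc4c3COB4O)c2)c1` has the same atoms as compound 3, joined differently: a group of 10 heavy atoms (7 carbon, 1 boron, 2 oxygen; one five-membered non-aromatic ring with 2 hetero atoms, one six-membered aromatic ring of carbon only) in place of a group of 10 heavy atoms (7 carbon, 1 boron, 2 oxygen; one five-membered non-aromatic ring with 2 hetero atoms, one six-membered aromatic ring of carbon only), on a saturated chain carbon, two bonds along the chain from a carbonyl carbon.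

All three measured steps are swaps of this same kind, and all lie beyond the scatter: a 70-fold higher number from compound 1 to compound 2 (1.84 log units; beyond the scatter), a 15-fold higher number from compound 2 to compound 3 (1.18 log units; beyond the scatter) and a 1100-fold higher number from compound 1 to compound 3 (3.02 log units; beyond the scatter). A large step is therefore expected here too. Its direction is less certain, but compound 3 at 56000 nM already sits at the weak end, so a lower number is the likelier outcome. Among the compounds with values here, no measured step covers this particular arrangement, so the range stays wide. The expected change is a 5.6-fold lower number from compound 3 to compound 4 (0.75 log units; beyond the scatter). For compound 4 the estimated value is 10000 nM, with an expected range of 1000 nM to 80000 nM.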

Compound 4, half-maximal inhibitory concentration: 50000 nM
Beside the measured number, compound 4's estimate is 5.0-fold (0.70 log units) below it; low and high end bracket the measured number.
By their numbers in this assay, from the lowest: compound 1; then compound 2; then compounds 4 and 3 (each within the scatter of the next).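

Within the data shown here, the step of a 1.1-fold lower number from compound 3 to compound 4 (0.05 log units; within the scatter) is the first swap of this kind that does not pass the scatter, so two isomeric boron-containing groups on this saturated chain carbon need not separate in this assay. The steps of a 14-fold higher number from compound 2 to compound 4 (1.13 log units; beyond the scatter) and a 940-fold higher number from compound 1 to compound 4 (2.97 log units; beyond the scatter) show that compound 4 shares the weak end with compound 3, so the large gaps seen so far belong to compound 1 and compound 2 rather than to every rearrangement of the group. Nothing available explains why these isomers differ or coincide.

On these data alone, it remains open whether the activity of compound 1 depends on boron at all, as a group with carbon in its place or an open boronic acid could show. A longer chain carrying the group of compound 1 is likewise untested here.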